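A few compounds are considered here, and "the series" means these few. Any claim that something is new, unique, unknown or untested is made for them only; others in the source may bear on it.

Measured so far:
- compound 1 `Fc1ccc(-c2nnc(SCCCN3CCN(c4nc5ccccc5o4)CC3)o2)cc1`: 83800 nM
- compound 2 `COc1ccc(-c2nnc(SCCCN3CCN(c4nc5ccccc5s4)CC3)o2)cc1`: 134000 nM

In a functional assay on HepG2 cells (Homo sapiens) for inhibition, read by MTT assay, with a stated time of 72 h (on this read-out higher numbers stand for weaker inhibition and lower numbers for stronger inhibition), compound 2 at 134000 nM lies within the scatter of compound 1 at 83800 nM, so the two cannot be told apart. Next is compound 3 `CC(C)(C)Oc1ccc(-c2nnc(SCCCN3CCN(c4nc5ccccc5s4)CC3)o2)cc1`, which differs from compound 2 by tert-butyl in place of methyl on an oxygen on an aromatic ring, with tert-butyl in place of methyl on an oxygen on an aromatic ring. For the measured compounds named here, no measured pair shows this change, so no step beyond the scatter is expected in this assay. The expected step is a 1.2-fold lower number from compound 2 to compound 3 (0.09 log units; within the scatter). Compound 3 is estimated at 110000 nM, with an expected range of 45000 nM to 260000 nM.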

Compound 3, half-maximal inhibitory concentration: 202000 nM
Compound 3: the middle estimate sits 1.8-fold (0.26 log units) below what was measured; the measured number falls inside the stated range.
By their numbers in this assay, from the lowest: compounds 1, 2 and 3 (each within the scatter of the next, the first and the last beyond it).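

For the compounds shown here, at the oxygen on the aromatic ring, methoxy to tert-butoxy gives a 1.5-fold higher number from compound 2 to compound 3 (0.18 log units; within the scatter) in this assay, the first one-place step. Tert-butyl, with 4 heavy atoms in place of the 1 of methyl, therefore leaves compound 3 indistinguishable from compound 2 on this read-out. No measurement at hand speaks to a cause for this result.

On these data alone, whether an amine or a carboxylic acid at this place would give a step beyond the scatter remains open. The same holds for a longer straight chain on the oxygen.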